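A few compounds are considered here, and "the series" means these few. Any claim that something is new, unique, unknown or untested is made for them only; others in the source may bear on it.

In a functional assay on BXPC-3 cells (Homo sapiens) for antiproliferative activity, read by MTT assay, with a stated time of 24 h (a higher number here means a weaker inhibitor, a lower number a stronger inhibitor), two amides sharing the same core have been measured so far. Compound 1 `CCn1c(C(=O)N[C@@H](C)CO)ccc1C(CC)(CC)c1ccc(OCS(=O)(=O)c2ccccc2)c(C)c1` gives 15300 nM, and compound 2 `CCn1c(C(=O)N[C@@H](CO)C(C)C)ccc1C(CC)(CC)c1ccc(OCS(=O)(=O)c2ccccc2)c(C)c1` gives 13200 nM. Going by the values given here, on these numbers compound 2 stands level with its only measured neighbour, and neither can be ranked above the other.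

Compound 3 `CCn1c(C(=O)NCCCO)ccc1C(CC)(CC)c1ccc(OCS(=O)(=O)c2ccccc2)c(C)c1` has not yet been measured. It carries 3-hydroxypropyl in place of 1-(hydroxymethyl)-2-methylpropyl on an amide-type nitrogen. The group that leaves holds a defined stereocentre, and the group that enters holds none.

Among the compounds with values here, one measured step bears on this change, since it swaps one group for another on the same amide-type nitrogen: 1-(hydroxymethyl)-2-methylpropyl in place of 1-(hydroxymethyl)ethyl gave a 1.2-fold lower number from compound 1 to compound 2 (0.06 log units; within the scatter). Within the data shown here, no measured compound carries 3-hydroxypropyl, so this single small step is thin support. Even so, it offers no reason to predict a large move in this assay, in either direction.

The expected step is a 1.1-fold higher number from compound 2 to compound 3 (0.03 log units; within the scatter), which means no real change is expected. For compound 3 the estimated value is 14000 nM, with an expected range from 7000 nM to 28000 nM.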

Compound 3, half-maximal inhibitory concentration: 26600 nM
Compound 3: middle estimate off by 1.9-fold (0.28 log units), on the low side; low and high end bracket the measured number.
By their numbers in this assay, from the lowest: compounds 2, 1 and 3 (each within the scatter of the next).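

In this assay, 3-hydroxypropyl on the amide-type nitrogen, with fewer heavy atoms than the earlier groups and no defined stereocentre, gives a 2.0-fold higher number from compound 2 to compound 3 (0.30 log units; within the scatter) when it replaces 1-(hydroxymethyl)-2-methylpropyl, and a 1.7-fold higher number from compound 1 to compound 3 (0.24 log units; within the scatter) when it replaces 1-(hydroxymethyl)ethyl. Going by these compounds alone, the earlier pair compared only two groups that each hold a defined stereocentre, whereas these steps show that a group without one also cannot be told apart from either of them at this position, although the step from the larger group is as big as a step can be while still counting as scatter. No measurement here offers an explanation for these small differences.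

As far as these compounds go, what remains open is whether any group on this nitrogen can move the number clearly beyond the scatter, for example an amine or a carboxylic acid in place of the hydroxy group, a longer chain such as 5-hydroxypentyl, or a cyclohexyl ring. The three compounds also leave open whether the mirror-image form of 1-(hydroxymethyl)-2-methylpropyl would behave like the form in compound 2.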